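The source may report more compounds than this note shows. Statements on the series, on what has been measured and on what is new or still open speak of the compounds shown alone.

Compound 1 `CNC(=O)c1ccc(-c2cnc3cnc(C(=O)N(C)c4ccc(C#N)cc4)cn23)cc1` has been measured in an ADME assay on the whole organism for pharmacokinetics, with Mus musculus as the target, at a dose of 20 mg/kg by the oral route (a higher number here means more compound in the circulation at the dose given, a lower number less compound in the circulation), where compound 1 gives 5200 nM. Among the compounds with values here, of the two numbers available, compound 1 has the lower, although the gap to its only neighbour lies within the usual scatter. That neighbour is compound 2 `CN(C(=O)c1cn2c(-c3ccc(C(N)=O)cc3)cnc2cn1)c1ccc(F)cc1`, which in this assay gives 8300 nM; the two values are so close that they show nothing more than agreement. Compound 3 `CN(C(=O)c1cn2c(-c3ccc(-c4nnc(N)s4)cc3)cnc2cn1)c1ccc(C#N)cc1` has not yet been measured in this assay. It differs from compound 1 in one place: 5-amino-1,3,4-thiadiazol-2-yl in place of methylcarbamoyl on an aromatic carbon. Within the data shown here, no measured pair shows what this exchange does to the number in this assay, so any expectation for compound 3 rests only on the position of compound 1 and on the agreement of the two measured compounds. The step is expected to be modest, a 1.5-fold lower number from compound 1 to compound 3 (0.17 log units; within the scatter), leaning toward a smaller number but not clearly beyond the scatter. For compound 3 in this assay the estimated value is 3500 nM, with a range from 1000 nM to 12000 nM.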

Compound 3, maximal plasma concentration: 20 nM
The estimate for compound 3 lay 180-fold (2.24 log units) above the measured number, and the stated range ends above it.
By their numbers in this assay, from the lowest: compound 3; then compounds 1 and 2 (each within the scatter of the next).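

In this assay, putting 5-amino-1,3,4-thiadiazol-2-yl in place of methylcarbamoyl on the six-membered aromatic ring of carbon only gives a 260-fold lower number from compound 1 to compound 3 (2.41 log units; beyond the scatter), so what sits at this position, para to a large group, can matter greatly in the whole animal. Both groups carry no net charge and the rest of the molecule stays the same, yet this single exchange is enough to take the maximal plasma concentration from a high level to a very low one. Nothing available here explains the drop, and the number alone cannot separate poor uptake from rapid removal or any other origin.

A single pair also leaves open whether the loss belongs to the five-membered ring as a whole, to its amino group or to its sulfur atom. The same ring without the amino group, a 1,3,4-oxadiazole ring with oxygen in place of the sulfur, or a carboxylic acid at this position would show how far the low number follows each of these features.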